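Formyl for Diethoxymethyl on the Chain: Estimating Compound 4

The source may report more compounds than this note shows. Statements on the series, on what has been measured and on what is new or still open speak of the compounds shown alone.

Measured so far:
Compound 1 `CCOC(CCn1c(Cc2nn(C)c(=O)c3ccccc23)nnc1SCC(=O)Nc1ccc(Cl)cc1Cl)OCC` sits at the limit of an assay on NK92 cells for inhibition of interleukin-2 (Homo sapiens), read by AlphaScreen, with stated times of 30 min and 1 h (a higher number here means a weaker inhibitor, a lower number a stronger inhibitor), giving > 30000 nM.
Compound 2 `CCOC(CCn1c(Cc2nn(C)c(=O)c3ccccc23)nnc1SCCCCCCCC(=O)Nc1ccc(Cl)cc1Cl)OCC` also gives only a limit, > 30000 nM.
Compound 3 `Cn1nc(Cc2nnc(SCC(=O)Nc3ccc(Cl)cc3Cl)n2CCC=O)c2ccccc2c1=O` gives 8600 nM in this assay.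

Compound 1 and compound 2 differ in the chain carrying the amide; the difference between the two cores is not broken down here. Compound 3 arises from compound 1 by formyl in place of diethoxymethyl on a saturated chain carbon, two bonds along the chain from an aromatic nitrogen, and that change gave an at least 3.4-fold lower number from compound 1 to compound 3 (0.54 log units; beyond the scatter). The step is known only as a lower bound because of the limit of > 30000 nM in this assay, at which 2 of the 3 values shown sit.

Compound 4 `Cn1nc(Cc2nnc(SCCCCCCCC(=O)Nc3ccc(Cl)cc3Cl)n2CCC=O)c2ccccc2c1=O` is made from compound 2 by formyl in place of diethoxymethyl on a saturated chain carbon, two bonds along the chain from an aromatic nitrogen, the same change at the same place. The measured result of this change was an at least 3.4-fold lower number from compound 1 to compound 3 (0.54 log units; beyond the scatter). In this assay the expected step is therefore an at least 3.0-fold lower number from compound 2 to compound 4 (0.47 log units; beyond the scatter). For compound 4 the estimated value is 10000 nM, ranging from 3000 nM to 30000 nM.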

Compound 4, half-maximal inhibitory concentration: 960 nM
Compound 4: the middle estimate sits 10-fold (1.02 log units) above what was measured; measured number below the stated range.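

Putting formyl in place of diethoxymethyl lowered the number on a second core in this assay, giving an at least 31-fold lower number from compound 2 to compound 4 (1.49 log units; beyond the scatter). The change therefore pointed the same way on both cores, but this does not show that it has the same size on each, as the two steps read: the same change on two cores in this assay, an at least 3.4-fold lower number (0.54 log units; beyond the scatter) from compound 1 to compound 3 and an at least 31-fold lower number (1.49 log units; beyond the scatter) from compound 2 to compound 4; the limit leaves it open whether they differ. Compound 1 and compound 2 each give only a limit, so neither step has an exact size: the limit of > 30000 nM in this assay, at which 2 of the 4 values shown sit.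

The compounds shown leave open whether formyl is special at this place, or whether a carboxylic acid, an amine or an alcohol there would also lower the number. They also leave open what a longer chain carrying the amide would do.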